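This account rests on a few compounds, and the source may have more. Where it says the series, first, only, none or still open, it means among the compounds named here.

Measured compounds:
compound 1, `Nc1cc(OCc2ccccc2F)c2nn[nH]c2n1`: 30 nM
compound 2, `Nc1cc(OCc2cccc(-c3cccc(F)c3)c2)c2nn[nH]c2n1`: 21 nM

Both values come from an assay for inhibition of Myeloperoxidase (Homo sapiens), read by Amplex Red, with stated times of 10 min and 15 min; on this read-out higher numbers stand for weaker inhibition and lower numbers for stronger inhibition. Compound 2 carries the lower of the two numbers, but compound 1 sits within the scatter of it, so the two are not separated. Compound 3, `Cn1cc(-c2cccc(COc3cc(N)nc4[nH]nnc34)c2)cn1`, is not yet measured; it differs from compound 2 in one place: 1-methyl-1H-pyrazol-4-yl in place of 3-fluorophenyl on an aromatic carbon. Among the measured compounds shown here, no step between measured compounds covers this kind of exchange, so nothing beyond the scatter is expected in this assay, in either direction. For compound 3 the expected value is 30 nM, within 10 nM to 90 nM. For compound 3 this estimate means a step of a 1.4-fold higher number from compound 2 to compound 3 (0.15 log units; within the scatter), expected to stay within the scatter.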

Compound 3, half-maximal inhibitory concentration: 78 nM
Beside the measured number, compound 3's estimate is 2.6-fold (0.41 log units) below it; low and high end bracket the measured number.
By their numbers in this assay, from the lowest: compounds 2 and 1 (each within the scatter of the next); then compound 3.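

In this assay, the group on this aromatic carbon is not freely exchangeable: 1-methyl-1H-pyrazol-4-yl in place of 3-fluorophenyl gives a 3.7-fold higher number from compound 2 to compound 3 (0.57 log units; beyond the scatter), a modest loss of inhibition. The number therefore depends on which aromatic ring occupies this place, though compound 3 still gives a nanomolar value. Nothing shown accounts for the step. Left open is where unsubstituted phenyl, pyridin-3-yl or the pyrazole without its methyl would fall relative to compound 2 and compound 3, which would help separate the roles of ring size, ring nitrogens and the methyl.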